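From 2-fluorobenzyl to 3-fluorobenzyl: compound 2 to compound 3

A few compounds are considered here, and "the series" means these few. Any claim that something is new, unique, unknown or untested is made for them only; others in the source may bear on it.

In a functional assay on cells (Platelet, Homo sapiens) for inhibition (on this read-out higher numbers stand for weaker inhibition and lower numbers for stronger inhibition), compound 1 `CCOC(=O)c1ccc(-c2nn(Cc3cccc(Cl)c3)c3ccccc23)cc1` gives > 10000 nM, a limit of the assay and not a number. As far as these compounds go, compound 2 `CCOC(=O)c1ccc(-c2nn(Cc3ccccc3F)c3ccccc23)cc1` gives > 10000 nM, also a limit and not a number, so its true position is unknown.

Compound 3 `CCOC(=O)c1ccc(-c2nn(Cc3cccc(F)c3)c3ccccc23)cc1` carries 3-fluorophenyl in place of 2-fluorophenyl, on a saturated chain carbon bound to an aromatic nitrogen: 3-fluorophenyl in place of 2-fluorophenyl on a saturated chain carbon bound to an aromatic nitrogen.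

Among the compounds with values here, the only measured step bearing on this change is a step that the two limits leave unreadable from compound 1 to compound 2, and it offers no size to carry forward. Within the data shown here, the series so far consists of the limit of > 10000 nM in this assay, at which 2 of the 2 values shown sit. With no readable step behind it, the expectation is for no change beyond the scatter and for no particular direction in this assay. The expected step is a number no higher from compound 2 to compound 3 (the limit leaves the size open). The estimate for compound 3 is 10000 nM, with an expected range from 3000 nM to 30000 nM.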

Compound 3, half-maximal inhibitory concentration: > 10000 nM
Compound 3 ended at the assay's limit; the forecaster's own chance of this, stated with the estimate: 85%; the middle value lies on the limit itself.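

No step among compound 1, compound 2 and compound 3 can be read in this assay, since each value is a limit and not a number: the limit of > 10000 nM in this assay, at which 3 of the 3 values shown sit.

Still open, as far as these compounds go, is whether 2-fluorophenyl, 3-fluorophenyl or 3-chlorophenyl differ at all in inhibition, since the true values of all three compounds remain unknown.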